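Methyl to Methoxy on the Triazole Aryl Group

The source may hold more compounds than are shown below. What is called first, only, known or untested is meant among the compounds shown, and "the series" means these compounds.

Measured so far in a functional assay on SW480 cells (Homo sapiens) for cytotoxicity, read by MTT assay, with a stated time of 4 days; a higher number here means a weaker inhibitor, a lower number a stronger inhibitor:
Compound 1 `C=C1C[C@]23C[C@@]1(O)CC[C@H]2c1ccc(OS(=O)(=O)c2ccc(C)cc2)c(C)c1[C@@H]3Cn1cc(-c2ccc(OC)cc2)nn1` gives > 20000 nM, which is a limit of this assay.
Compound 2 `C=C1C[C@]23C[C@@]1(O)CC[C@H]2c1ccc(OS(=O)(=O)c2ccc(C)cc2)c(C)c1[C@@H]3Cn1cc(-c2ccc(C)cc2)nn1` gives > 20000 nM, also a limit.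
Compound 3 `C=C1C(=O)[C@]23C[C@@]1(O)CC[C@H]2c1ccc(O)c(C)c1[C@@H]3Cn1cc(-c2ccc(C)cc2)nn1` gives 330 nM.

Compound 1 and compound 2 differ by methoxy in place of methyl on an aromatic carbon. The step that the two limits leave unreadable from compound 2 to compound 1 cannot be read, since both sit at the limit of > 20000 nM in this assay, at which 2 of the 3 values shown sit. Compound 3 has a different core from compound 2; that difference is not broken down here. Compound 4 `C=C1C(=O)[C@]23C[C@@]1(O)CC[C@H]2c1ccc(O)c(C)c1[C@@H]3Cn1cc(-c2ccc(OC)cc2)nn1` is not yet measured and differs from compound 3 by methoxy in place of methyl on an aromatic carbon, the same kind of change as between compound 2 and compound 1, at the same place. Because the earlier step that the two limits leave unreadable from compound 2 to compound 1 gives no readable size, the expectation for compound 4 rests on compound 3 alone, and the step is expected to be small: a 1.2-fold higher number from compound 3 to compound 4 (0.08 log units; within the scatter). Compound 4 is therefore estimated at 400 nM in this assay, between 150 nM and 1200 nM.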

Compound 4, half-maximal inhibitory concentration: 220 nM
Compound 4: middle estimate off by 1.8-fold (0.26 log units), on the high side; the range from low to high includes it.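

On the core of compound 3, going from 4-methylphenyl to 4-methoxyphenyl in this assay gives a 1.5-fold lower number from compound 3 to compound 4 (0.18 log units; within the scatter), so on this core the two groups cannot be told apart. On the core of compound 2, the same change cannot be read, since compound 2 and compound 1 both rest at a limit of the assay: the limit of > 20000 nM in this assay, at which 2 of the 4 values shown sit. The series therefore offers one readable example of this change, which does not show that it behaves alike on both cores.

Open, on these data alone, is how an amine or a carboxylic acid at the same place on the ring would fare on the core of compound 3. Also open, as far as these compounds go, is which part of the difference between the two cores separates the limit values from the measured ones.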